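The compounds below may be only part of what the source reports. "The series", "measured", "known", "first", "only" and "open" are said of these compounds alone.

Measured so far in a functional assay on HeLa cells (Homo sapiens) for antiproliferative activity, read by CCK-8 assay, with a stated time of 48 h; on this read-out lower numbers stand for stronger inhibition and higher numbers for weaker inhibition:
- compound 1, `O=c1c2ccccc2[se]n1-c1nc(SCc2ccccc2)n[nH]1`: > 50000 nM
- compound 2, `CCCCSc1n[nH]c(-n2[se]c3ccccc3c2=O)n1`: 32900 nM

Compound 1 stands at the edge of what this assay reports: its value > 50000 nM is a limit of the assay and not a number (the limit of > 50000 nM in this assay, at which 1 of the 2 values shown sits). Within the data shown here, compound 2 is the only compound of the set with a number, 32900 nM, so the series as a whole shows weak inhibition. Among the measured compounds shown here, the single measured step, an at least 1.5-fold lower number from compound 1 to compound 2 (0.18 log units; that floor lies within the scatter), concerns propyl in place of phenyl on a saturated chain carbon bound to a sulfur and rests on the limit of compound 1, so its true size is open.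

Compound 3, `O=c1c2ccccc2[se]n1-c1nc(SCc2ccc([N+](=O)[O-])cc2)n[nH]1`, differs from compound 1 by nitro in place of hydrogen on an aromatic carbon. For the measured compounds named here, no measured step touches the six-membered aromatic ring of carbon only: the step from compound 1 to compound 2 removes that ring rather than substitutes it, so nothing here bears on a nitro at this place. The step of an at least 1.1-fold lower number from compound 1 to compound 3 (0.04 log units; that floor lies within the scatter) is therefore expected to stay within the scatter, with no direction favoured. Compound 3 is expected to give about 45000 nM in this assay, within 15000 nM to 150000 nM, and likely to return only a limit again.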

Compound 3, half-maximal inhibitory concentration: 3940 nM
Compound 3: middle estimate off by 11-fold (1.06 log units), on the high side; the measured number lies below the stated range.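

In this assay, the six-membered aromatic ring of carbon only now proves to be a place where a substituent can matter: nitro in place of hydrogen, para to a large group, goes with an at least 12-fold lower number from compound 1 to compound 3 (1.10 log units; beyond the scatter). Among these compounds, the earlier step, an at least 1.5-fold lower number from compound 1 to compound 2 (0.18 log units; that floor lies within the scatter), removed that ring and did not substitute it, so it could not show this, and compound 3 gives the first step of the set that is beyond the scatter. The value of compound 1, > 50000 nM, is a limit of the assay and not a number, so the step is a floor and its true size remains open: the limit of > 50000 nM in this assay, at which 1 of the 3 values shown sits.

A single substituted compound cannot show whether this step belongs to nitro itself or would also appear with another group on the same carbon, such as an amine, a methoxy group or a chlorine atom. Also open, from the compounds shown here alone, is how a longer chain in place of the phenyl would read in this assay, and whether nitro on a different carbon of the ring would give a step of similar size.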